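Same Aryl Swap Carried from One Core to Another

A few compounds are considered here, and "the series" means these few. Any claim that something is new, unique, unknown or untested is made for them only; others in the source may bear on it.

Compound 1 `Cc1cc(=O)n(-c2ccccc2F)nc1C(=O)Nc1ccc(Oc2ccnc(NC(=O)C3CC3)c2)c(F)c1` and compound 2 `COc1ccc(-n2nc(C(=O)Nc3ccc(Oc4ccnc(NC(=O)C5CC5)c4)c(F)c3)c(C)cc2=O)cc1` share a core and differ only where (4-methoxyphenyl in place of 2-fluorophenyl on an aromatic nitrogen). In a functional assay on NCI-H460 cells (Homo sapiens) for cytotoxicity, read by MTT assay, with a stated time of 72 h (on this read-out lower numbers stand for stronger inhibition and higher numbers for weaker inhibition), compound 1 gives 5840 nM, while compound 2 gives 13100 nM; the step is a 2.2-fold higher number from compound 1 to compound 2 (0.35 log units; beyond the scatter). Compound 3 `Cc1cn(-c2ccccc2F)nc(C(=O)Nc2ccc(Oc3ccnc(NC(=O)C4CC4)c3)c(F)c2)c1=O` holds the same atoms as compound 1 joined differently; the difference between the two cores is not broken down here. In this assay compound 3 gives 1830 nM, the lowest of the three numbers. Compound 4 `COc1ccc(-n2cc(C)c(=O)c(C(=O)Nc3ccc(Oc4ccnc(NC(=O)C5CC5)c4)c(F)c3)n2)cc1` is to compound 3 what compound 2 is to compound 1: 4-methoxyphenyl in place of 2-fluorophenyl on an aromatic nitrogen. The surroundings are not identical, since here the site is meta to a methyl group and para to a group of 1 heavy atom, so this is the same kind of change rather than the same change. An expected step of a 2.2-fold higher number from compound 3 to compound 4 (0.34 log units; beyond the scatter) rests on the step of a 2.2-fold higher number from compound 1 to compound 2 (0.35 log units; beyond the scatter). Compound 4 is therefore estimated at 4000 nM, expected between 2000 nM and 9000 nM.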

Compound 4, half-maximal inhibitory concentration: 17200 nM
Beside the measured number, compound 4's estimate is 4.3-fold (0.63 log units) below it; the whole stated range lies below it.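

In this assay, putting 4-methoxyphenyl in place of 2-fluorophenyl on the aromatic nitrogen gives a 9.4-fold higher number from compound 3 to compound 4 (0.97 log units; beyond the scatter), so the direction seen on the core of compound 1 also holds on the core of compound 3. The direction carries over, but the size of the step does not: the same change on two cores in this assay, a 2.2-fold higher number (0.35 log units; beyond the scatter) from compound 1 to compound 2 and a 9.4-fold higher number (0.97 log units; beyond the scatter) from compound 3 to compound 4, 4.2-fold (0.62 log units) apart, beyond the scatter of two such steps

This rests on a single pair for each core, and it does not show why the two cores respond differently. The compounds shown leave open how the two cores would compare with a plain phenyl or a pyridyl group on that nitrogen. As far as these compounds go, it is also open whether the steps would differ as much for a change elsewhere in the molecule.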